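Swapping the furan for an oxazole on the shared core

This account rests on a few compounds, and the source may have more. Where it says the series, first, only, none or still open, it means among the compounds named here.

Compound 1 `Cc1ccc(-c2nc(N)c3cc(-c4ccccc4)sc3n2)o1`: 520 nM
Compound 2 `Cc1ccc(-c2nc(N)c3cc(Cc4ccccc4F)sc3n2)o1`: < 16 nM, a limit
Compound 3 `CC(C)c1ccc(-c2nc(N)c3cc(Cc4ccccc4)sc3n2)o1`: 283 nM

In a functional assay on CHO-K1 cells for antagonist activity at adenosine receptor A1 (Homo sapiens), read by a beta-galactosidase reporter and cAMP accumulation, with stated times of 15 min and 6 h (a lower number here means a stronger inhibitor, a higher number a weaker inhibitor), compound 3 gives 283 nM, one of only two plain numbers shown; compound 1 gives 520 nM, a gap within the usual scatter, so the two cannot be told apart. Compound 2 sits at the limit of < 16 nM in this assay, at which 1 of the 3 values shown sits, which is a boundary of the assay and not a number. Going by the values given here, the single measured step, an at least 32-fold lower number from compound 1 to compound 2 (1.51 log units; beyond the scatter), changes the other side of the core, so it does not bear on the present change. Compound 4 `Nc1nc(-c2ncco2)nc2sc(Cc3ccccc3)cc12` differs from compound 3 by 1,3-oxazol-2-yl in place of 5-isopropylfuran-2-yl on an aromatic carbon. Among the compounds with values here, with no measured step touching this change, the direction is open, and compound 4 is expected to give about 150 nM, between 30 nM and 800 nM. The step of a 1.9-fold lower number from compound 3 to compound 4 (0.28 log units; within the scatter) is an estimate, not a measurement.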

Compound 4, inhibition constant: 310 nM
Compound 4: the middle estimate sits 2.1-fold (0.32 log units) below what was measured; measured number inside the range.
By their numbers in this assay, from the lowest: compounds 3, 4 and 1 (each within the scatter of the next). At a limit, below all of these: compound 2.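

Placed on the shared core, 1,3-oxazol-2-yl instead of 5-isopropylfuran-2-yl gives a 1.1-fold higher number from compound 3 to compound 4 (0.04 log units; within the scatter) in this assay. At this position, then, a ring group of 5 heavy atoms with 2 hetero atoms can stand in for one of 8 heavy atoms with 1 hetero atom, with no readable shift in the number. Nothing measured here explains this outcome. From the compounds shown here alone, whether an amine or a longer chain at this position would leave the number unmoved stays open. Also open, going by these compounds, is how 1,3-oxazol-2-yl would behave alongside the 2-fluorobenzyl group of compound 2.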